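Sulfonamide series on a benzoxazole core: truncating the sulfonyl substituent

The source may hold more compounds than are shown below. What is called first, only, known or untested is meant among the compounds shown, and "the series" means these compounds.

Measured compounds:
- compound 1, `O=S(=O)(Nc1ccc(-c2nc3ccccc3o2)cc1)c1cccs1`: 63000 nM
- compound 2, `O=S(=O)(Nc1ccc2oc(-c3ccccc3)nc2c1)c1cccc(C(F)(F)F)c1`: > 100000 nM
- compound 3, `O=S(=O)(Nc1ccc2oc(-c3ccccc3)nc2c1)c1ccccc1Cl`: > 100000 nM

Three sulfonamides built on a shared core have been tested in an assay on cells for inhibition of HSP60/HSP10 (Homo sapiens), with a stated time of 60 min; a higher number here means a weaker inhibitor, a lower number a stronger inhibitor. Compound 1 is the only one of the three for which this assay returns a number, and in this assay compound 1 gives 63000 nM. For compound 2 this assay reports only a limit, > 100000 nM. For compound 3 this assay likewise reports only a limit, > 100000 nM. Thus (the limit of > 100000 nM in this assay, at which 2 of the 3 values shown sit), and compound 1 stands as the one resolved value of the set, itself a weak one.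

The next compound, compound 4, `CS(=O)(=O)Nc1ccc(-c2nc3ccccc3o2)cc1`, keeps the core and the sulfonamide of compound 1 and changes the group on the sulfonyl sulfur: methyl in place of thiophen-2-yl on a sulfonyl sulfur. Among the measured compounds shown here, no measured pair in the set differs by exactly this change, so the size of the step is not known from the data.

Expectation: given that compound 1 already gives only a weak value of 63000 nM, and that removing the aromatic ring from the sulfonyl sulfur leaves a much smaller substituent, the step from compound 1 to compound 4 is expected to run toward weaker inhibition by about a 1.9-fold higher number from compound 1 to compound 4 (0.28 log units; within the scatter), possibly beyond the scatter. Compound 4 is therefore estimated at 120000 nM, with a range of 50000 nM to 300000 nM, and a substantial chance that this assay returns only a limit.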

Compound 4, half-maximal inhibitory concentration: > 100000 nM
Compound 4 gave a limit, no number; the forecaster's own chance of this, stated with the estimate: 60%; the middle value does not contradict the limit.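

In this assay, among the compounds shown here, methyl in place of thiophen-2-yl on a sulfonyl sulfur gives an at least 1.5-fold higher number from compound 1 to compound 4 (0.20 log units; that floor lies within the scatter), the first step read at this position with the core and the sulfonamide held fixed. Since the floor of this step lies within the scatter, the pair shows no firm loss, only that swapping the five-membered aromatic ring for methyl brings no gain that the assay can detect, and that any value for compound 4 remains unresolved. The one change at this position takes the series from a single number on compound 1 to one more limit, so the only resolved value still depends on the thiophen-2-yl group: the limit of > 100000 nM in this assay, at which 3 of the 4 values shown sit.

As far as these compounds go, how far compound 4 lies past its limit stays open, and so does the true size of the step, which could be small or large. Also open, from the compounds shown here alone, is whether the ring itself matters or whether another group on the sulfonyl sulfur, such as phenyl, a longer chain like n-butyl, or an amine like dimethylamino, would give a stronger value than compound 1 on the same core.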